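From pyridin-3-yl to pyridin-4-yl on compound 1

The source may report more compounds than this note shows. Statements on the series, on what has been measured and on what is new or still open speak of the compounds shown alone.

In a functional assay on HepG2 cells (Homo sapiens) for cytotoxicity, read by MTT assay, with a stated time of 24 h (a lower number here means a stronger inhibitor, a higher number a weaker inhibitor), compound 1 `COc1cc(/C=C2\CN(C)C/C(=C\c3cccnc3)C2=O)cc(OC)c1OC` reads 9520 nM and compound 2 `CN1C/C(=C\c2ccc(C(F)(F)F)cc2)C(=O)/C(=C/c2cccnc2)C1` reads 4790 nM with the two values within the scatter of each other. Within the data shown here, compound 1 therefore stands level with the only other measured compound, and no order can be drawn between them.

Among the measured compounds shown here, compound 3 `COc1cc(/C=C2\CN(C)C/C(=C\c3ccncc3)C2=O)cc(OC)c1OC` has no measurement yet. It differs from compound 1 by pyridin-4-yl in place of pyridin-3-yl on a double-bonded chain carbon bound to a double-bonded ring carbon. The two have the same atoms, joined differently. For the measured compounds named here, no measured pair shows this swap, so a step no larger than the scatter is expected in this assay with no firm direction. The expectation therefore rests on compound 1 at 9520 nM as the closest measured reference. The estimated change is a 1.2-fold lower number from compound 1 to compound 3 (0.08 log units; within the scatter) and stays within the scatter. For compound 3 the expected value is 8000 nM (estimated range 3500 nM to 18000 nM).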

Compound 3, half-maximal inhibitory concentration: 9800 nM
The estimate for compound 3 lay 1.2-fold (0.09 log units) below the measured number; the range from low to high includes it.
By their numbers in this assay, from the lowest: compounds 2, 1 and 3 (each within the scatter of the next, the first and the last beyond it).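

Pyridin-4-yl in place of pyridin-3-yl on a double-bonded chain carbon bound to a double-bonded ring carbon gives, in this assay, a 1.0-fold higher number from compound 1 to compound 3 (0.01 log units; within the scatter), the first single-place step in the series. On the core of compound 1, this assay therefore does not separate the two pyridine isomers, which have the same atoms joined differently, and no order can be drawn between them. No supporting data bear on why the swap leaves the reading within the scatter.

On these data alone, whether this place accepts other groups without a larger step stays open, for example pyridin-2-yl or a phenyl ring carrying an amine or a carboxylic acid. Also open, as far as these compounds go, is whether the same swap would read alike on the core of compound 2, since this single step comes from the core of compound 1 and says nothing about another group on the far side of the molecule's shared core.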